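Trading a Carbonyl for a Hydroxyl on the Ether Chain

This account rests on a few compounds, and the source may have more. Where it says the series, first, only, none or still open, it means among the compounds named here.

Of the compounds shown here, three sharing one core have been measured in an assay on HL-60 cells for agonist activity at vitamin D3 receptor (Homo sapiens), read by microscopy, with a stated time of 96 h; on this read-out higher numbers stand for an effect only at larger amounts of compound and lower numbers for an effect already at smaller amounts. Compound 1 `CCN(CC)CCNC(=O)c1ccc(C(CC)(CC)c2ccc(OCC(O)C(C)(C)C)c(C)c2)n1CC` gives 110 nM, and compound 2 `CCn1c(C(=O)NCC(OC)OC)ccc1C(CC)(CC)c1ccc(OCC(O)C(C)(C)C)c(C)c1` gives 150 nM; the step between them, a 1.4-fold higher number from compound 1 to compound 2 (0.13 log units; within the scatter), shows no difference that can be distinguished. Compound 3 `CCn1c(C(=O)N(C)CC(=O)O)ccc1C(CC)(CC)c1ccc(OCC(=O)C(C)(C)C)c(C)c1` gives 1390 nM, the highest of the three numbers: compound 2 is the nearest and compound 1 the furthest, both gaps beyond the scatter. Compound 3 differs from the other two in two places at once, at the amide side and on the chain bound to the aromatic oxygen, so the measured values do not say which of the two goes with its position.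

Compound 4 `CCn1c(C(=O)N(C)CC(=O)O)ccc1C(CC)(CC)c1ccc(OCC(O)C(C)(C)C)c(C)c1` keeps the amide of compound 3 and alters only the chain: 1-hydroxy-2,2-dimethylpropyl in place of (tert-butyl)carbonyl on a saturated chain carbon bound to an oxygen on an aromatic ring. Within the data shown here, the group that enters is the one carried by compounds 1 and 2. Among the measured compounds shown here, no measured step covers this change; the only measured step concerns the amide side and lies within the scatter. The expectation therefore rests on compounds 1 and 2 carrying the hydroxyl at lower numbers than compound 3. Compound 4 is expected to come in lower than compound 3, by a 3.5-fold lower number from compound 3 to compound 4 (0.54 log units; beyond the scatter). The estimate for compound 4 in this assay is 400 nM, between 100 nM and 1500 nM.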

Compound 4, half-maximal effective concentration: 740 nM
The estimate for compound 4 lay 1.9-fold (0.27 log units) below the measured number, and the stated range covers the measured number.
By their numbers in this assay, from the lowest: compounds 1 and 2 (each within the scatter of the next); then compounds 4 and 3 (each within the scatter of the next).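

With the amide of compound 3 held fixed, the step at the saturated chain carbon bound to an oxygen on an aromatic ring in this assay is a 1.9-fold lower number from compound 3 to compound 4 (0.27 log units; within the scatter), so trading (tert-butyl)carbonyl for 1-hydroxy-2,2-dimethylpropyl gives no difference that can be distinguished in this amide setting. With the hydroxyl chain held fixed, the amide side does separate the compounds: the steps are a 4.9-fold higher number from compound 2 to compound 4 (0.69 log units; beyond the scatter) and a 6.7-fold higher number from compound 1 to compound 4 (0.83 log units; beyond the scatter), both modest and both beyond the scatter, so among these single-place comparisons only the change to (carboxymethyl)(methyl)amino on the carbonyl carbon produces a readable shift. Nothing available gives a reason for either the flat chain step or the amide steps.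

On these data alone, the chain change has been read against this one amide only, so it remains open whether (tert-butyl)carbonyl would stand as close to the hydroxyl chain when paired with the amide of compound 1 or compound 2. Also open, as far as these compounds go, is how an amine in place of the hydroxyl on the 2-hydroxy-3,3-dimethylbutoxy chain, or a methyl ester in place of the carboxylic acid on the amide side, would read in this assay.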